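This account rests on a few compounds, and the source may have more. Where it says the series, first, only, none or still open, it means among the compounds named here.

Measured compounds:
compound 1, `CCCc1nc(C)n2c(O)nncc12`, > 48000 nM (a limit)
compound 2, `CCOC(=O)Cn1ncc2cncn2c1=O`, > 48000 nM (a limit)
compound 3, `C=CCn1ncc2cncn2c1=O`, > 48000 nM (a limit)

In a functional assay for inhibition, with Homo sapiens as the target (on this read-out higher numbers stand for weaker inhibition and lower numbers for stronger inhibition), compound 3 gives > 48000 nM, which is a limit of the assay and not a number. The same holds for compound 1, whose value in this assay is > 48000 nM, a limit. Compound 2 likewise stands at a limit in this assay, > 48000 nM. Among the compounds with values here, the only measured step, a step that the two limits leave unreadable from compound 2 to compound 3, is therefore unreadable, since both of its ends sit at the limit of > 48000 nM in this assay, at which 3 of the 3 values shown sit.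

Compound 4, `C=CCn1ncc2cnc(C)n2c1=O`, differs from compound 3 by methyl in place of hydrogen on an aromatic carbon. Within the data shown here, no measured step bears on this change, and the one measured step gives no readable size. Compound 1 also carries a methyl and sits at the limit, which is all its value shows. Because all three values rest at the limit of > 48000 nM in this assay, at which 3 of the 3 values shown sit, compound 4 is expected to remain at the limit as well, so that a step that the limit leaves unreadable from compound 3 to compound 4 is expected to be no readable step. Compound 4 is estimated at 70000 nM, with a range from 25000 nM to 200000 nM.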

Compound 4, half-maximal inhibitory concentration: > 48000 nM
Compound 4 was reported as a limit (the forecaster's own chance of this, stated with the estimate: 80%); the middle value lies beyond the limit too.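

No step can be read between compound 3 and compound 4, since both stand at the same limit: the limit of > 48000 nM in this assay, at which 4 of the 4 values shown sit.

The compounds shown leave open how strongly any of them inhibits in this assay, and whether methyl in place of hydrogen on an aromatic carbon changes that at all.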